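This account rests on a few compounds, and the source may have more. Where it says the series, first, only, none or still open, it means among the compounds named here.

Series values in an in vitro ADME assay on microsomes from liver (Homo sapiens) for pharmacokinetics, read by LC-MS; a lower number here means slower removal, a higher number faster removal of the compound:
- compound 1 `Cc1cccc2c1nc(C)n2-c1ccc(C(=O)NC2CC2)s1`: 10 mL/min/kg
- compound 2 `Cc1ccc2nc(C)n(-c3ccc(C(=O)NC4CC4)s3)c2c1`: 10 mL/min/kg
- compound 3 `Cc1nc2ccc(F)cc2n1-c1ccc(C(=O)NC2CC2)s1`: < 4 mL/min/kg
- compound 4 `Cc1nc2c(C#N)cccc2n1-c1ccc(C(=O)NC2CC2)s1`: not yet measured

Among the measured compounds shown here, compound 1 stands level with compound 2, the only other compound with an exact number, and the two are within the scatter. For compound 3 the reading is a limit of the assay and not a number.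

The next change is cyano in place of methyl on an aromatic carbon. For the measured compounds named here, one measured step bears on it, fluoro in place of methyl on an aromatic carbon, an at least 2.5-fold lower number from compound 2 to compound 3 (0.39 log units; beyond the scatter). That step ends at the limit of < 4 mL/min/kg in this assay, at which 1 of the 3 values shown sits, so its true size is not known. Going by the values given here, no measured compound carries a cyano group, which makes this only a loose guide. A lower number in this assay is therefore expected, of modest size and possibly close to the scatter. The estimated step is a 2.0-fold lower number from compound 1 to compound 4 (0.30 log units; within the scatter). Compound 4 is expected at 5 mL/min/kg, with an estimated range of 2.5 mL/min/kg to 10 mL/min/kg.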

Compound 4, clearance: < 4 mL/min/kg
Compound 4 ended at the assay's limit; the forecaster's own chance of this, stated with the estimate: 35%; at least 1.2-fold (0.09 log units) between middle value and limit.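

In this assay, the methyl on this aromatic carbon, ortho to a fused ring, now has a measured replacement, and cyano in place of methyl gives an at least 2.5-fold lower number from compound 1 to compound 4 (0.39 log units; beyond the scatter). Among the compounds shown here, this is the only measured step at this carbon and the only one involving a nitrile, so a lower number is no longer seen solely with the fluoro change, which sits on a different carbon of the shared core. The true size of the step remains unknown because compound 4 gave a limit of the assay, not a number: the limit of < 4 mL/min/kg in this assay, at which 2 of the 4 values shown sit.

The compounds shown leave open whether fluoro on this same carbon would match cyano, and whether a methoxy group or an amine there would also give a lower number. They also cannot rank compound 3 against compound 4, as both readings are limits.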